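This account rests on a few compounds, and the source may have more. Where it says the series, first, only, none or still open, it means among the compounds named here.

Working notes on the benzimidazole-free summary of the series, followed in an ADME assay on MT4 cells (Homo sapiens) for cytotoxicity; a lower number here means that less compound is tolerated, a higher number that more compound is tolerated.

Compound 1 `COC(=O)c1ccc(NC(=O)CSc2nc3ccc(Cl)cc3n2Cc2cc(C)cc(C)c2)c(Cl)c1` gives 105000 nM in this assay. Compound 2 `COC(=O)c1ccc(NC(=O)CSc2nc3ccc(Cl)cc3n2S(=O)(=O)c2cc(C)cc(C)c2)c(Cl)c1` differs from it by one change, ((3,5-dimethylphenyl)sulfonyl in place of 3,5-dimethylbenzyl on an aromatic nitrogen). For compound 2 this assay returns >= 130000 nM, which is a limit of the assay and not a number. The step of an at least 1.2-fold higher number from compound 1 to compound 2 (0.09 log units; that floor lies within the scatter) therefore rests on the limit of >= 130000 nM in this assay, at which 1 of the 3 values shown sits, and only a floor is known for it; that floor lies within the usual scatter.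

Compound 3 `Cc1cc(C)cc(Cn2c(SCC(=O)Nc3ccc(S(C)(=O)=O)cc3Cl)nc3ccccc32)c1` gives 106000 nM in this assay. The difference between the core of compound 3 and the core of compound 1 is not broken down here. The value of compound 3 and the value of compound 1 lie within the scatter of each other, so no order between them is stated.

Compound 4 `Cc1cc(C)cc(S(=O)(=O)n2c(SCC(=O)Nc3ccc(S(C)(=O)=O)cc3Cl)nc3ccccc32)c1` is not yet measured. Relative to compound 3 it carries (3,5-dimethylphenyl)sulfonyl in place of 3,5-dimethylbenzyl on an aromatic nitrogen. This is the same change as that from compound 1 to compound 2, made at the same place on the aromatic nitrogen, and it occurs twice among the compounds shown.

For the step from compound 3 to compound 4 a change of about a 1.2-fold higher number from compound 3 to compound 4 (0.09 log units; within the scatter) is expected in this assay, resting on the earlier step of an at least 1.2-fold higher number from compound 1 to compound 2 (0.09 log units; that floor lies within the scatter) and on the starting value that compound 3 gives, 106000 nM. For compound 4 the expected value in this assay is 130000 nM, with a likely range from 85000 nM to 210000 nM. Since compound 2 came back as a limit, compound 4 may well do the same; the measurement will tell.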

Compound 4, half-maximal cytotoxic concentration: > 221000 nM
Compound 4: a limit, no number; the forecaster's own chance of this, stated with the estimate: 50%; at least 1.7-fold (0.23 log units) between middle value and limit.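

In this assay, (3,5-dimethylphenyl)sulfonyl in place of 3,5-dimethylbenzyl on the aromatic nitrogen gives an at least 2.0-fold higher number from compound 3 to compound 4 (0.31 log units; beyond the scatter), so on the core of compound 3 the step is beyond the scatter even though only its floor is known. Compound 4 gives > 221000 nM, which is a limit of the assay and not a number. The change therefore clears the scatter on only one of the two cores, since the floor on the core of compound 1 stays within it, and the two limits do not show whether the change carries over with the same size, or even whether it is larger on one core than on the other: the same change on two cores in this assay, an at least 1.2-fold higher number (0.09 log units; that floor lies within the scatter) from compound 1 to compound 2 and an at least 2.0-fold higher number (0.31 log units; beyond the scatter) from compound 3 to compound 4; the limit leaves it open whether they differ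

The true values of compound 2 and compound 4 remain open, and with them any real comparison of the step on the two cores, whose differences are not separated by the compounds shown. Also open, going by these compounds, is whether the same result would follow with a benzoyl group or a longer carbon chain linking the aromatic nitrogen to the 3,5-dimethylphenyl ring, or with an amine or a carboxylic acid on that ring.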